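This account rests on a few compounds, and the source may have more. Where it says the series, first, only, none or still open, it means among the compounds named here.

Measured so far:
Compound 1 `CC(C)n1ncc2c(C(=O)NCc3cn(-c4ccccc4)nn3)cccc21` gives > 40000 nM in a functional assay on HepG2 cells (Homo sapiens) for inhibition, read by MTT assay, with a stated time of 72 h (on this read-out higher numbers stand for weaker inhibition and lower numbers for stronger inhibition), a limit of the assay rather than a number.
Compound 2 `CC(C)n1ncc2c(C(=O)NCc3cn(-c4cccc(F)c4)nn3)cccc21` gives > 40000 nM in this assay, again a limit.
Compound 3 `CC(C)n1ncc2c(C(=O)NCc3cn(Cc4ccc(C#N)cc4)nn3)cccc21` gives > 40000 nM in this assay, also a limit.

Compound 3 therefore stands at the edge of what this assay can report: its value is only a limit, and the same holds for the two other compounds, as shown by the limit of > 40000 nM in this assay, at which 3 of the 3 values shown sit. The step to the unmeasured compound 4 `COc1ccc(Cn2cc(CNC(=O)c3cccc4c3cnn4C(C)C)nn2)cc1` is a single change: methoxy in place of cyano on an aromatic carbon. Three measured steps share the same setting, but each of them runs between two limits, so none gives a readable size: a step that the two limits leave unreadable from compound 1 to compound 2, a step that the two limits leave unreadable from compound 1 to compound 3 and a step that the two limits leave unreadable from compound 2 to compound 3. Within the data shown here, they show only that changes on the group attached to the aromatic nitrogen, whether a fluoro is added, or a phenyl is exchanged for a 4-cyanobenzyl, have not brought any compound inside the measurable range. On this basis no step beyond the scatter is expected for a step that the limit leaves unreadable from compound 3 to compound 4, and the most likely outcome is that compound 4 is again reported as a limit. The estimate for compound 4 in this assay is accordingly 50000 nM, within a range from 15000 nM to 200000 nM.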

Compound 4, half-maximal inhibitory concentration: > 40000 nM
Compound 4 was reported as a limit; the forecaster's own chance of this, stated with the estimate: 85%; the middle value does not contradict the limit.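

Compound 4 is also reported only as a limit, like compound 1, compound 2 and compound 3, so none of its steps to those three compounds can be read: the limit of > 40000 nM in this assay, at which 4 of the 4 values shown sit. The compounds shown leave open how strongly each one inhibits in this assay, and whether any other group on the aromatic nitrogen would give a measurable value.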